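The source may hold more compounds than are shown below. What is called first, only, known or untested is meant among the compounds shown, and "the series" means these compounds.

Of the compounds shown here, two sharing one core have been tested so far. Compound 1 `COc1cc(-c2cc(/C=C/C(=O)c3ccc(N)cc3)[nH]n2)cc(OC)c1OC` and compound 2 `COc1ccc(C(=O)/C=C/c2cc(-c3cc(OC)c(OC)c(OC)c3)n[nH]2)cc1OC` were both measured in a functional assay on HOP-62 cells (Homo sapiens) for inhibition, read by sulforhodamine B assay, with a stated time of 48 h; a higher number here means a weaker inhibitor of growth, a lower number a stronger inhibitor of growth. In this assay compound 1 gives 3920 nM, and compound 2 gives 2770 nM. Within the data shown here, the only step between them, a 1.4-fold lower number from compound 1 to compound 2 (0.15 log units; within the scatter), is within the scatter, so the two numbers cannot be told apart; compound 2 simply stands alongside compound 1, with nothing else yet to compare against.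

Compound 3 `COc1ccc(C(=O)/C=C/c2cc(-c3cc(OC)c(OC)c(OC)c3)n[nH]2)cc1` is the next member. It differs from compound 2 by hydrogen in place of methoxy on an aromatic carbon, ortho to a methoxy group and meta to a large group. Among the measured compounds shown here, the one measured step that bears on this change, a 1.4-fold lower number from compound 1 to compound 2 (0.15 log units; within the scatter), swapped the whole aryl group on the carbonyl carbon and still moved the number by less than the scatter, so a smaller trimming of that same ring is expected to leave the number roughly where it is. Compound 3 is therefore expected to give about 3000 nM in this assay, most likely between 1400 nM and 6500 nM. The estimated step from compound 2 to compound 3, a 1.1-fold higher number from compound 2 to compound 3 (0.03 log units; within the scatter), is expected to fall within the scatter.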

Compound 3, concentration for total growth inhibition: 3770 nM
The estimate for compound 3 lay 1.3-fold (0.10 log units) below the measured number; the range from low to high includes it.
By their numbers in this assay, from the lowest: compounds 2, 3 and 1 (each within the scatter of the next).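

In this assay the 3,4-dimethoxyphenyl group of compound 2 can give way to the 4-methoxyphenyl group of compound 3 with no readable consequence (a 1.4-fold higher number from compound 2 to compound 3 (0.13 log units; within the scatter)). So the methoxy group that leaves, ortho to a methoxy group, is not needed to keep the number at this level. Compound 3 also allows a tighter comparison than the earlier step, as it differs from compound 1 only in carrying methoxy in place of amino on that ring, and these two groups cannot be told apart here either (a 1.0-fold lower number from compound 1 to compound 3 (0.02 log units; within the scatter)); no measurement at hand offers an explanation for this flat picture.

Going by these compounds, all three compounds lie within the scatter of one another, so it remains open whether any group on this ring can move the number beyond the scatter, for instance a hydroxy group, a carboxylic acid or a longer chain such as butoxy, or a plain phenyl ring with no group at all. The compounds shown also share the same trimethoxyphenyl group at the other end of the core, so what that group contributes to growth inhibition stays open as well.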